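Methoxy in place of the oxazole on a silent core

The source may report more compounds than this note shows. Statements on the series, on what has been measured and on what is new or still open speak of the compounds shown alone.

Compound 1 `Cc1oncc1-c1cccc2c1CCC2c1ncc[nH]1`: > 10000 nM, a limit of the assay.
Compound 2 `CCS(=O)(=O)Nc1cccc(Cc2c[nH]cn2)c1`: > 10000 nM, a limit of the assay.

In a functional assay on CHO cells for agonist activity at Alpha-1B adrenergic receptor (Homo sapiens), read by FLIPR and calcium flux (a higher number here means that more compound is needed for the effect, a lower number that less compound is needed), compound 1 gives > 10000 nM, which is a limit of the assay and not a number. Compound 2 also gives only a limit there, > 10000 nM. Going by the values given here, both values sit at the limit of > 10000 nM in this assay, at which 2 of the 2 values shown sit, so compound 1 stands at the limit itself and no measured step is known. Compound 3 `COc1cccc2c1CCC2c1ncc[nH]1` differs from compound 1 by methoxy in place of 5-methyl-1,2-oxazol-4-yl on an aromatic carbon. With nothing measured to build on, compound 3 is expected to show a step that the limit leaves unreadable from compound 1 to compound 3, that is, none beyond the scatter. Compound 3 is estimated at 12000 nM, between 2500 nM and 50000 nM.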

Compound 3, half-maximal effective concentration: > 10000 nM
Compound 3 ended at the assay's limit; the forecaster's own chance of this, stated with the estimate: 65%; the middle value is on the limit's open side.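

No step can be read from compound 1 to compound 3, since both end at a limit of the assay and not at a number: the limit of > 10000 nM in this assay, at which 3 of the 3 values shown sit.

The compounds shown leave open whether any group on this aromatic carbon of the shared core can give a measurable value in this assay at all.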